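The source may hold more compounds than are shown below. What is called first, only, known or untested is meant among the compounds shown, and "the series" means these compounds.

In a functional assay on A549 cells (Homo sapiens) for inhibition, read by MTT assay, tested at 10 uM (on this read-out lower numbers stand for less inhibition and higher numbers for more inhibition at the one concentration tested (going by the name of the read-out)), compound 1 `CC1Cc2ccccc2N1S(=O)(=O)c1ccc(-c2cnc(C3CC3)o2)cc1` gives 52.4%, compound 2 `CS(=O)(=O)c1ccc2c(c1)CCN2S(=O)(=O)c1ccc(-c2cnc(C3CC3)o2)cc1` gives 4.14%, and compound 3 `O=[N+]([O-])c1ccc2c(c1)CCN2S(=O)(=O)c1ccc(-c2cnc(C3CC3)o2)cc1` gives 73.1%.

Compound 3 stands highest of the three, beyond the scatter from compound 1 and far beyond it from compound 2. Compound 4 `O=S(=O)(c1ccc(-c2cnc(C3CC3)o2)cc1)N1CCc2cc(F)ccc21` differs from compound 3 in one place: fluoro in place of nitro on an aromatic carbon. One measured step changes the same position: a number 69 percentage points higher from compound 2 to compound 3 (beyond the scatter), so what sits there can swing the read-out greatly. Among the measured compounds shown here, no measured step tells what fluoro does there, and compound 1 shows only that a compound without nitro can still give a middling value. For compound 4 a downward step is expected, a number 33.1 percentage points lower from compound 3 to compound 4 (beyond the scatter), with wide uncertainty. Compound 4 is thus expected at 40%, with a range from 10% to 70%.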

Compound 4, a percentage reported as inhibition, at one concentration (the size of the read-out at that concentration, not a potency): 36.1%
Compound 4: middle estimate off by 3.9 percentage points, on the high side; low and high end bracket the measured number.
By their numbers in this assay, from the lowest: compound 2; then compound 4; then compound 1; then compound 3.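

In this assay fluoro on this aromatic carbon gives a number 37 percentage points lower from compound 3 to compound 4 (beyond the scatter) and a number 32 percentage points higher from compound 2 to compound 4 (beyond the scatter) so compound 4 sits clearly apart from both neighbours in the series. This position therefore does not act as a simple on-off switch: among these three groups the read-out rises from methylsulfonyl through fluoro to nitro. Nothing available here explains why these groups differ. Going by these compounds, whether an amine, a carboxylic acid or a methoxy group on this carbon would fall within this range remains open. Also open, on these data alone, is whether the same order would hold on another carbon of this ring.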